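Swapping Cyclopropyl for 4-Methoxyphenyl on the Ring Amide Nitrogen

The source may hold more compounds than are shown below. What is called first, only, known or untested is meant among the compounds shown, and "the series" means these compounds.

Measured compounds:
compound 1 `O=C1COc2ccc(-c3cccc(NS(=O)(=O)c4ccc(F)cc4)c3)cc2N1C1CC1` — > 40000 nM
compound 2 `COc1ncc(-c2ccc3c(c2)NC(=O)CO3)cc1NS(=O)(=O)c1ccc(F)cc1` — 7110 nM

Of the compounds shown here, two have been measured in a functional assay on HeLa cells (Homo sapiens) for antiproliferative activity, read by MTT assay, with a stated time of 72 h; a lower number here means a stronger inhibitor, a higher number a weaker inhibitor. Compound 1 returns only a limit in this assay, > 40000 nM, so compound 1 stands at the limit of > 40000 nM in this assay, at which 1 of the 2 values shown sits, and no number is known for it. Compound 2 gives 7110 nM in this assay. Among the compounds with values here, the two differ from each other in more than one place, so no single step between them can be read. Compound 3 `COc1ccc(N2C(=O)COc3ccc(-c4cccc(NS(=O)(=O)c5ccc(F)cc5)c4)cc32)cc1` is unmeasured and differs from compound 1 in one place: 4-methoxyphenyl in place of cyclopropyl on an amide-type nitrogen in a ring. Within the data shown here, with compound 1 resting at the limit of > 40000 nM in this assay, at which 1 of the 2 values shown sits, no measured step anchors the size or direction of this change, so the account expects a step no larger than the scatter, most likely leaving compound 3 at a limit as well. Compound 3 is therefore expected to give about 35000 nM, within 8000 nM to 100000 nM, in this assay. That expectation corresponds to a step of an at least 1.1-fold lower number from compound 1 to compound 3 (0.05 log units; that floor lies within the scatter).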

Compound 3, half-maximal inhibitory concentration: 13200 nM
Compound 3: the middle estimate sits 2.7-fold (0.42 log units) above what was measured; measured number inside the range.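

In this assay, within the data shown here, 4-methoxyphenyl in place of cyclopropyl on the amide-type nitrogen in a ring gives an at least 3.0-fold lower number from compound 1 to compound 3 (0.48 log units; beyond the scatter), the first step that can be read at this position. The change brings the compound from a limit to a measured number, so this nitrogen can carry a six-membered aromatic ring with a methoxy group without losing all measurable activity. As far as these compounds go, the true size of the step remains unknown, and only its floor can be read, because compound 1 gives a limit and not a number: the limit of > 40000 nM in this assay, at which 1 of the 3 values shown sits.

From the compounds shown here alone, it remains open whether the step belongs to the aromatic ring itself or to its methoxy group, which a plain phenyl on the same nitrogen would separate. Going by these compounds, how an amine-bearing chain or a longer alkyl chain would fare at this position also remains open.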